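A few compounds are considered here, and "the series" means these few. Any claim that something is new, unique, unknown or untested is made for them only; others in the source may bear on it.

Working notes on a small series sharing one core. Compound 1 `C/C(=N\OC(C)C(=O)O)c1ccc(Cl)cc1` in a functional assay on the whole organism for inhibition, with Rattus norvegicus as the target, read by paw edema, with stated times of 1 h and 3 h (on this read-out higher numbers stand for an effect only at larger amounts of compound and lower numbers for an effect already at smaller amounts), gives 55 mg/kg. Compound 2 `C/C(=N\OC(C)(C)C(=O)O)c1ccc(Cl)cc1` differs from it by methyl in place of hydrogen on a saturated chain carbon bound to a carbonyl carbon, an oxygen and a saturated chain carbon; in this assay compound 2 gives 42 mg/kg, so that a 1.3-fold lower number from compound 1 to compound 2 (0.12 log units; within the scatter). Compound 3 `CCOC(=O)CO/N=C(\C)c1ccc(Cl)cc1` carries a different core; how its core differs from that of compound 1 is not broken down here. In this assay compound 3 gives 32 mg/kg. Compound 4 `CCCOC(=O)CO/N=C(\C)c1ccc(Cl)cc1` has not yet been measured in this assay. It differs from compound 3 by methyl in place of hydrogen on a saturated chain carbon, two bonds along the chain from an oxygen next to a carbonyl group. Among the measured compounds shown here, this is the same kind of change as the one from compound 1 to compound 2, not the same one: there the carbon carrying the new methyl is bound to a carbonyl carbon, an oxygen and a saturated chain carbon, whereas here it stands two bonds along the chain from an oxygen next to a carbonyl group. The earlier step, a 1.3-fold lower number from compound 1 to compound 2 (0.12 log units; within the scatter), was small. Here a step of similar size is expected, a 1.1-fold lower number from compound 3 to compound 4 (0.03 log units; within the scatter), resting only on that precedent a 1.3-fold lower number from compound 1 to compound 2 (0.12 log units; within the scatter) and on compound 3 as the starting point. Compound 4 is accordingly estimated at 30 mg/kg, with a likely range from 15 mg/kg to 60 mg/kg.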

Compound 4, dose for half-maximal effect: 14 mg/kg
Compound 4: the middle estimate sits 2.1-fold (0.33 log units) above what was measured, and the stated range ends above it.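

In this assay, among the compounds shown here, methyl in place of hydrogen gives a 2.3-fold lower number from compound 3 to compound 4 (0.36 log units; beyond the scatter), and this is the only step of the two that lies beyond the scatter. Set beside the earlier step, it does not differ by more than repeated measurement allows: the same change on two cores in this assay, a 1.3-fold lower number (0.12 log units; within the scatter) from compound 1 to compound 2 and a 2.3-fold lower number (0.36 log units; beyond the scatter) from compound 3 to compound 4, 1.7-fold (0.24 log units) apart, within the scatter of two such steps. The two steps are therefore compatible with this kind of change carrying over from one core to the other, but they do not establish that it does: each core supplies a single pair, the carbon taking the methyl is not the same in the two cases, and the earlier step cannot be told apart from the scatter.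

The compounds shown leave open whether a longer chain than propoxy on the core of compound 3 would extend this step, leave the number unchanged or reverse it. From the compounds shown here alone, it also remains open how an amine in place of the propoxy group would read on this core.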